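A few compounds are considered here, and "the series" means these few. Any claim that something is new, unique, unknown or untested is made for them only; others in the source may bear on it.

Measured so far:
compound 1, `CCCCN(CC)C(=O)c1sc(Nc2c(Cl)cc(Cl)cc2Cl)nc1C`: 2800 nM
compound 2, `CCCN(Cc1sc(Nc2c(C)cc(C)cc2Cl)nc1C(F)(F)F)CC1CC1`: 23 nM

The two measured compounds differ in more than one place, so their values are taken only as they stand. In an assay for displacement of a labelled ligand from corticotropin-releasing factor receptor 1 (Homo sapiens) (on this read-out lower numbers stand for stronger inhibition and higher numbers for weaker inhibition), compound 1 gives 2800 nM, and compound 2 gives 23 nM. Compound 2 therefore holds the lowest number of the two, and the gap to compound 1 lies beyond the scatter of the assay.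

Compound 3, `CCCN(Cc1sc(Nc2c(Br)cc(Br)cc2Br)nc1C(F)(F)F)CC1CC1`, has not yet been measured. It differs from compound 2 in one place: 2,4,6-tribromophenyl in place of 2-chloro-4,6-dimethylphenyl on a nitrogen on an aromatic ring. Every other part of compound 2 is kept unchanged.

Going by the values given here, no step between two measured compounds shows what this change alone does, so the expectation rests on compound 2 alone. Because compound 2 gives 23 nM and the exchanged group keeps its size and ring type, compound 3 is expected to land within the scatter of compound 2, with a step of a 1.5-fold higher number from compound 2 to compound 3 (0.18 log units; within the scatter) that may go slightly either way. The estimate for compound 3 in this assay is 35 nM, with a range from 10 nM to 150 nM.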

Compound 3, inhibition constant: 7.8 nM
Estimate against measurement, compound 3: 4.5-fold (0.65 log units) above; the measured number lies below the stated range.
By their numbers in this assay, from the lowest: compound 3; then compound 2; then compound 1.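

In this assay, putting 2,4,6-tribromophenyl in place of 2-chloro-4,6-dimethylphenyl on a nitrogen on an aromatic ring gives a 2.9-fold lower number from compound 2 to compound 3 (0.47 log units; beyond the scatter), a modest step that goes in the favourable direction on this read-out. Going by these compounds alone, this is the first change that can be read in one place, and it shows that the group on this nitrogen can move the number even when the entering and leaving groups match in heavy-atom count, in their one six-membered aromatic ring of carbon only, and in having no hydrogen-bond donors or acceptors. Nothing measured here accounts for the step, so it stands as an observation without an explanation.

With a single pair, the compounds shown leave open whether the step follows from having bromine at all three named ring positions or from losing the methyl groups and the chlorine, and a 2,4,6-trimethylphenyl group or a ring carrying methoxy groups at those positions would test this. They also leave open whether the same exchange would have a similar effect with a different side chain on the shared core, such as a longer chain on the amine.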